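Swapping the Sulfonyl Aryl Group in a Serotonin Receptor Series

A few compounds are considered here, and "the series" means these few. Any claim that something is new, unique, unknown or untested is made for them only; others in the source may bear on it.

Measured so far, in a functional assay on CHO cells for antagonist activity at 5-hydroxytryptamine receptor 6 (Homo sapiens), read by FLIPR; on this read-out lower numbers stand for stronger inhibition and higher numbers for weaker inhibition:
compound 1 `COc1ccc(S(=O)(=O)N2CC(C(=O)N(C)C3CCN(C)CC3)c3ccccc32)c2ccccc12` gives 7.94 nM;
compound 2 `COc1ccc(S(=O)(=O)N2CC(C(=O)NC3CCN(C)CC3)c3ccccc32)c2ccccc12` gives 25.1 nM;
compound 3 `CN1CCC(N(C)C(=O)C2CN(S(=O)(=O)c3ccc4ccccc4c3)c3ccccc32)CC1` gives 25.1 nM.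

Compound 3 stands level with compound 2, and these two share the highest numbers of the three; compound 1 has a lower number than compound 3, beyond the scatter. Compound 4 `CN1CCC(N(C)C(=O)C2CN(S(=O)(=O)c3ccc(C(F)(F)F)cc3)c3ccccc32)CC1` differs from compound 3 by 4-(trifluoromethyl)phenyl in place of naphthalen-2-yl on a sulfonyl sulfur. Among the compounds with values here, the one measured step, a 3.2-fold higher number from compound 1 to compound 2 (0.50 log units; beyond the scatter), concerns the amide nitrogen, not the sulfonyl group, so it says nothing direct about this change. Within the data shown here, with no step that bears on it, compound 4 is expected to land near compound 3, with a slight lean toward a higher number, a step of a 1.6-fold higher number from compound 3 to compound 4 (0.20 log units; within the scatter). Compound 4 is therefore estimated at 40 nM, within 12 nM to 160 nM.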

Compound 4, inhibition constant: 25.1 nM
Beside the measured number, compound 4's estimate is 1.6-fold (0.20 log units) above it, and the stated range covers the measured number.
By their numbers in this assay, from the lowest: compound 1; then compounds 2, 3 and 4 (each within the scatter of the next).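

In this assay this change on a sulfonyl sulfur gives no change at the digits printed from compound 3 to compound 4 (within the scatter) even though two aromatic rings give way to one. At this position, then, a single ring carrying trifluoromethyl reads the same as naphthalen-2-yl, with the heavy-atom count unchanged. Nothing available explains why these two groups read alike.

The compounds shown leave open whether the trifluoromethyl group matters, since an unsubstituted phenyl ring is not among them. They also leave open how a group such as an amine or a carboxylic acid on that ring would read.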